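A few compounds are considered here, and "the series" means these few. Any claim that something is new, unique, unknown or untested is made for them only; others in the source may bear on it.

Working notes on the series.

Compound 1 `Cc1cc(/C=C/C(=O)O)cc(C)c1Oc1ccc([N+](=O)[O-])c(Nc2ccc(C#N)cc2)n1` is the nitro-bearing reference; in an ADME assay on MT2 cells (Homo sapiens) for cytotoxicity, read by XTT assay, with a stated time of 4 days (on this read-out lower numbers stand for higher toxicity in this test and higher numbers for lower toxicity in this test), compound 1 gives 34800 nM. Compound 2 `Cc1cc(/C=C/C(=O)O)cc(C)c1Oc1ccc(N)c(Nc2ccc(C#N)cc2)n1` carries the change amino in place of nitro on an aromatic carbon and in this assay compound 2 gives 15700 nM. The resulting step is a 2.2-fold lower number from compound 1 to compound 2 (0.35 log units; beyond the scatter).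

Compound 3 `Cc1cc(/C=C/C#N)cc(C)c1Oc1cc(Nc2ccc(C#N)cc2)c(N)cc1[N+](=O)[O-]` rests on a different core; how the two cores differ is not broken down here. In this assay compound 3 gives 88200 nM, the highest of the three numbers, with both gaps to compound 1 and compound 2 beyond the scatter.

Compound 4 `Cc1cc(/C=C/C#N)cc(C)c1Oc1cc(Nc2ccc(C#N)cc2)c(N)cc1N` is not yet measured. It differs from compound 3 by amino in place of nitro on an aromatic carbon, the same kind of change as made from compound 1 to compound 2, but set differently: on a six-membered aromatic ring of carbon only, ortho to a large group, meta to an amino group and para to a (4-cyanophenyl)amino group, rather than on a ring with one nitrogen, ortho to the (4-cyanophenyl)amino group, two atoms from the ring nitrogen and para to a large group.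

Going by the values given here, because a 2.2-fold lower number from compound 1 to compound 2 (0.35 log units; beyond the scatter) was a modest lowering, a step of about the same size is expected from compound 3 to compound 4, a 2.2-fold lower number from compound 3 to compound 4 (0.34 log units; beyond the scatter), though the surroundings differ and the single precedent carries little weight. Compound 4 is estimated at 40000 nM, plausibly between 15000 nM and 100000 nM.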

Compound 4, half-maximal cytotoxic concentration: 18900 nM
Compound 4: middle estimate off by 2.1-fold (0.33 log units), on the high side; measured number inside the range.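

In this assay the amino-for-nitro change gives a 4.7-fold lower number from compound 3 to compound 4 (0.67 log units; beyond the scatter) and so lowers the number on the second core as well, which means the direction of the change holds in both pairs shown. The size of the step cannot be told apart between the two cores: the same change on two cores in this assay, a 2.2-fold lower number (0.35 log units; beyond the scatter) from compound 1 to compound 2 and a 4.7-fold lower number (0.67 log units; beyond the scatter) from compound 3 to compound 4, 2.1-fold (0.32 log units) apart, within the scatter of two such steps. This rests on two pairs only, so it supports carrying the change between these two cores but does not show that direction or size would hold on any further core, and it gives no reason for the lowering.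

As far as these compounds go, whether an acetamide in the same place would fall with the amino compounds or with the nitro compounds remains open. Going by these compounds alone, also open is how the change behaves with the carboxylic acid on the core of compound 3 or with the nitrile on the core of compound 1, since each core appears here with only one of these two groups.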